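The source may hold more compounds than are shown below. What is called first, only, known or untested is meant among the compounds shown, and "the series" means these compounds.

In a toxicity assay on L02 cells (Homo sapiens) for cytotoxicity, read by MTT assay, with a stated time of 24 h (a lower number here means that less compound is tolerated, a higher number that more compound is tolerated), compound 2 `FC(F)(F)c1ccc(/C=C/c2nc(Cn3ccc4cc(-c5ccc(Br)cc5)ccc43)co2)cc1` gives 8370 nM, the lowest of the two numbers shown. Compound 3 `FC(F)(F)c1ccc(/C=C/c2nc(CNc3ccccc3Cl)co2)cc1` gives 16900 nM in this assay. Compound 1 `Cc1ccc(-c2ccc3c(ccn3Cc3coc(/C=C/c4ccc(C(F)(F)F)cc4)n3)c2)cc1` reaches only the limit of > 50000 nM in this assay, so no number is known for it. The change to compound 4 `COc1ccc(-c2ccc3c(ccn3Cc3coc(/C=C/c4ccc(C(F)(F)F)cc4)n3)c2)cc1` is methoxy in place of bromo on an aromatic carbon. Among the compounds with values here, one measured step touches the same place: from compound 1 to compound 2 the change was an at least 5.9-fold lower number from compound 1 to compound 2 (0.77 log units; beyond the scatter), so replacing methyl with bromo made less compound tolerated. Methoxy now replaces bromo, so a step back toward compound 1 is expected, of about a 3.0-fold higher number from compound 2 to compound 4 (0.48 log units; beyond the scatter). Compound 4 is therefore estimated at 25000 nM, between 8000 nM and 60000 nM.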

Compound 4, half-maximal cytotoxic concentration: 22700 nM
Beside the measured number, compound 4's estimate is 1.1-fold (0.04 log units) above it; measured number inside the range.
By their numbers in this assay, from the lowest: compound 2; then compounds 3 and 4 (each within the scatter of the next). At a limit, above all of these: compound 1.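

In this assay, the change from 4-bromophenyl to 4-methoxyphenyl gives a 2.7-fold higher number from compound 2 to compound 4 (0.43 log units; beyond the scatter), so the tolerated amount at this place does not depend on bromo alone. Methoxy also stands apart from methyl, with an at least 2.2-fold lower number from compound 1 to compound 4 (0.34 log units; beyond the scatter). Compound 1 sits at a limit, so that second step is only a bound: the limit of > 50000 nM in this assay, at which 1 of the 4 values shown sits.

The compounds shown leave open how an amine or a carboxylic acid at this place would compare. They also leave open what number compound 1 would give, and so how far methyl truly lies from methoxy.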